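The source may report more compounds than this note shows. Statements on the series, on what has been measured and on what is new or still open speak of the compounds shown alone.

Compound 1 `COc1ccc(C2CC(c3ccccc3)=NN2C(=O)c2ccco2)cc1` was examined in an assay on isolated protein for inhibition of DNA topoisomerase 1 (Homo sapiens), with a stated time of 30 min, tested at 100 uM (on this read-out higher numbers stand for more inhibition at the one concentration tested (going by the name of the read-out) and lower numbers for less inhibition), where compound 1 gives 0%. A second compound measured in the same setting, compound 2 `O=C(c1ccncc1)N1N=C(c2ccc(Cl)cc2)CC1c1ccco1`, gives 0% in this assay. Compound 1 therefore stands level with compound 2 at the digits shown, and the two values lie within the scatter of each other, so nothing separates them. Neither compound shows inhibition at the single concentration tested.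

Compound 3 `COc1ccc(C2CC(c3ccccc3)=NN2C(=O)c2ccncc2)cc1` has not yet been measured in this assay. It arises from compound 1 by a single change: pyridin-4-yl in place of furan-2-yl on a carbonyl carbon. Among the measured compounds shown here, no measured pair shows this change directly, so the size of the step can only be anticipated. Compound 2 already carries a (pyridin-4-yl)carbonyl and gives 0% in this assay, a reading that sits at the bottom of the scale. On that basis the expected step is no change at the digits printed from compound 1 to compound 3 (within the scatter), none beyond the scatter. Compound 3 is accordingly estimated at 0% in this assay, with a range from 0% to 10%.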

Compound 3, a percentage reported as inhibition, at one concentration (the size of the read-out at that concentration, not a potency): 0%
The estimate for compound 3 equals the measured number at the digits printed; measured number inside the range.
By their numbers in this assay, from the lowest: compounds 1, 2 and 3 (each within the scatter of the next).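

In this assay, among the compounds shown here, pyridin-4-yl in place of furan-2-yl on a carbonyl carbon gives no change at the digits printed from compound 1 to compound 3 (within the scatter), and this is the first direct reading of this change, as the earlier compounds offered no pair that showed it. On the core of compound 1, neither of these two rings on the carbonyl carbon brings out inhibition at the one concentration tested. For the compounds shown here, all the readings sit at the bottom of the scale, however, so the step shows only that this swap does not lift the reading from there, and it cannot tell how the two groups would compare on a compound that does show inhibition.

As far as these compounds go, it remains open whether an amine, a carboxylic acid or a longer alkyl chain on this carbonyl carbon would give any reading above the bottom of the scale. From the compounds shown here alone, it is equally open whether a change elsewhere on the shared core would give a starting point from which this position could be compared at all. Nothing given here offers an explanation for the unchanged reading.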